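Compound 1 to compound 4: removing the methyl

This account rests on a few compounds, and the source may have more. Where it says the series, first, only, none or still open, it means among the compounds named here.

In a functional assay on A549 cells (Homo sapiens) for antiproliferative activity, read by MTT assay, with a stated time of 48 h (on this read-out higher numbers stand for weaker inhibition and lower numbers for stronger inhibition), compound 1 (`Cc1ccc(-c2nnc(NC(=O)/C=C/c3ccc(C(F)(F)F)cc3)s2)cc1`) gives 1.61 ug/mL as its measured value. Compound 2 (`COc1ccc(/C=C/C(=O)Nc2nnc(-c3ccc(C)cc3)s2)cc1`) gives 0.66 ug/mL and compound 3 (`Cc1ccc(/C=C/C(=O)Nc2nnc(-c3ccc(C)cc3)s2)cc1`) gives 1.08 ug/mL in the same read-out. For the measured compounds named here, only one step from compound 1 clears the scatter (a 2.4-fold lower number from compound 1 to compound 2 (0.39 log units; beyond the scatter)), while the other does not (a 1.5-fold lower number from compound 1 to compound 3 (0.17 log units; within the scatter)). The remaining step also stays inside it (a 1.6-fold higher number from compound 2 to compound 3 (0.21 log units; within the scatter)).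

Compound 4 (`O=C(/C=C/c1ccc(C(F)(F)F)cc1)Nc1nnc(-c2ccccc2)s1`) keeps the trifluoromethyl group of compound 1 and loses a methyl (hydrogen in place of methyl on an aromatic carbon): hydrogen in place of methyl on an aromatic carbon, para to a large group, so that 4-methylphenyl becomes phenyl.

Going by the values given here, no measured step touches this place. All three exchange trifluoromethyl, methoxy and methyl on a different aromatic ring, so they bear on the change only indirectly. They show the size of step that single small exchanges have given in this series, and the largest is modest (a 2.4-fold lower number from compound 1 to compound 2 (0.39 log units; beyond the scatter)). The closest exchange in kind, involving a methyl, stays within the scatter (a 1.5-fold lower number from compound 1 to compound 3 (0.17 log units; within the scatter)). No step beyond the scatter is therefore expected, and the data favour no direction. An estimated 1.1-fold higher number from compound 1 to compound 4 (0.05 log units; within the scatter) is expected. Compound 4 is estimated at 1.8 ug/mL (range 0.7 ug/mL to 4.5 ug/mL) as its expected value in this assay once measured.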

Compound 4, half-maximal inhibitory concentration: 1.78 ug/mL
Compound 4: middle estimate off by 1.0-fold (0.00 log units), on the high side; the range from low to high includes it.
By their numbers in this assay, from the lowest: compounds 2, 3, 1 and 4 (each within the scatter of the next, the first and the last beyond it).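

In this assay, for the compounds shown here, the exchange of 4-methylphenyl for phenyl gives a 1.1-fold higher number from compound 1 to compound 4 (0.04 log units; within the scatter), the first reading at this position, and it places compound 1 and compound 4 within the scatter of each other. Going by these compounds alone, with trifluoromethyl held on the other aromatic ring, the methyl on this aromatic carbon, para to a large group, is therefore not required to keep the read-out at the level of compound 1, whereas the only step beyond the scatter so far remains an exchange on the other ring, a 2.4-fold lower number from compound 1 to compound 2 (0.39 log units; beyond the scatter). No measurement available here bears on the reason for this result.

From the compounds shown here alone, this reading rests on a single exchange in a single background, so it remains open whether hydrogen in place of methyl would also stay within the scatter with methoxy or methyl on the other ring. It also leaves open how far the position accepts groups of a different kind, such as an amine, a carboxylic acid or a longer chain like butyl, on the same aromatic carbon.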